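Ethyl to tert-butyl on a short series

This account rests on a few compounds, and the source may have more. Where it says the series, first, only, none or still open, it means among the compounds named here.

In a functional assay on A549 cells (Homo sapiens) for cytotoxicity, read by MTT assay, with a stated time of 72 h (on this read-out higher numbers stand for weaker inhibition and lower numbers for stronger inhibition), compound 1 `CCCCOC1OC(=O)C(Cl)=C1Cl` gives 22500 nM, while compound 2 `CCOC1OC(=O)C(Cl)=C1Cl` gives 6300 nM. Among the compounds with values here, compound 2 therefore holds the lower of the two numbers so far, which makes it the stronger inhibitor of this pair. The next compound, compound 3 `CC(C)(C)OC1OC(=O)C(Cl)=C1Cl`, keeps the shared core and differs from compound 2 by tert-butyl in place of ethyl on an oxygen on a saturated carbon. Within the data shown here, only one measured step bears on this change: shortening the chain gave a 3.6-fold lower number from compound 1 to compound 2 (0.55 log units; beyond the scatter). Here the group grows instead, so the number in this assay is expected to rise, although no branched group has been measured yet. The expected change is a 2.2-fold higher number from compound 2 to compound 3 (0.35 log units; beyond the scatter). The estimated value for compound 3 is 14000 nM, within an expected range of 6000 nM to 35000 nM.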

Compound 3, half-maximal inhibitory concentration: 14000 nM
Beside the measured number, compound 3's estimate shows no gap at the digits printed, and the stated range covers the measured number.
By their numbers in this assay, from the lowest: compound 2; then compounds 3 and 1 (each within the scatter of the next).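

On this oxygen in this assay, a branched group can now be set against straight chains. Tert-butyl in place of ethyl gives a 2.2-fold higher number from compound 2 to compound 3 (0.35 log units; beyond the scatter), so ethyl still holds the lowest number of the three, while tert-butyl in place of butyl gives a 1.6-fold lower number from compound 1 to compound 3 (0.21 log units; within the scatter), so those two groups cannot be told apart on this read-out. No supporting measurement is available to explain why the group on this oxygen moves the number.

From the compounds shown here alone, what a methyl group, a longer chain such as hexyl, or a chain ending in an amine would do at this place remains open. Within the data shown here, with only three groups in one assay, it is also unclear whether the lower number seen with ethyl would hold beyond this short series.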